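Fluoro entering the anilino ring of the quinazoline-thioether series

A few compounds are considered here, and "the series" means these few. Any claim that something is new, unique, unknown or untested is made for them only; others in the source may bear on it.

Three members of this series have been measured in a functional assay on NCI-H1975 cells (Homo sapiens) for inhibition, read by MTT assay, with a stated time of 72 h; a higher number here means a weaker inhibitor, a lower number a stronger inhibitor. Compound 1 `O=C(CSc1nc(Nc2ccccc2)c2ccccc2n1)Nc1ccccc1Cl` gives 9610 nM, compound 2 `O=C(CSc1nc(Nc2ccccc2)c2ccccc2n1)Nc1cccc(Cl)c1` gives 8460 nM, and compound 3 `C=CC(=O)Nc1cccc(NC(=O)CSc2nc(Nc3cccc(Cl)c3)c3ccccc3n2)c1` gives 9460 nM. The three numbers lie within the scatter of one another, so no order among them can be read; compound 3 sits in the middle of a flat set. For the measured compounds named here, the one recorded step between compounds differing in a single place, a 1.1-fold lower number from compound 1 to compound 2 (0.06 log units; within the scatter), concerns the chloro position on the amide-type aryl and stays within the scatter.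

Going by the values given here, compound 4 `C=CC(=O)Nc1cccc(NC(=O)CSc2nc(Nc3ccc(F)c(Cl)c3)c3ccccc3n2)c1` differs from compound 3 by fluoro in place of hydrogen on an aromatic carbon, a change on the anilino ring that no measured pair probes. Among the compounds with values here, the only step available, a 1.1-fold lower number from compound 1 to compound 2 (0.06 log units; within the scatter), shows a halogen rearrangement elsewhere in the molecule leaving the number essentially unchanged, and the three values together show the series so far to be insensitive to aryl substitution. On that basis no step beyond the scatter is expected in this assay for compound 4, that is a 1.1-fold lower number from compound 3 to compound 4 (0.02 log units; within the scatter). Compound 4 is therefore estimated at 9000 nM, with a range from 4500 nM to 18000 nM.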

Compound 4, half-maximal inhibitory concentration: > 50000 nM
Compound 4: no number, only a limit; the forecaster's own chance of this, stated with the estimate: 5%; at least 5.5-fold (0.74 log units) between middle value and limit.
By their numbers in this assay, from the lowest: compounds 2, 3 and 1 (each within the scatter of the next). At a limit, above all of these: compound 4.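

Going from 3-chlorophenyl to 3-chloro-4-fluorophenyl, with fluoro entering ortho to a chloro group and para to a large group, gives an at least 5.2-fold higher number from compound 3 to compound 4 (0.72 log units; beyond the scatter), the first recorded step in the series that lies beyond the scatter. For the compounds shown here, this position on the anilino ring therefore responds in this assay, although the flat values of compounds 1, 2 and 3 gave no sign of it, and the only earlier step, a 1.1-fold lower number from compound 1 to compound 2 (0.06 log units; within the scatter), concerned the chloro position on the amide-type aryl and stayed within the scatter. Compound 4 gives > 50000 nM, which is a limit and not a number, so the step has a lower bound but no measured size: the limit of > 50000 nM in this assay, at which 1 of the 4 values shown sits.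

What remains open is whether this response is specific to fluoro or extends to other groups at the same position, as only hydrogen and fluoro are shown there; a methoxy group, an amine or a second chloro group would help to separate these cases. Going by these compounds alone, also open is whether the step holds on another background, as only one pair carries this change.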